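Working notes: from compound 3 to compound 4

This account rests on a few compounds, and the source may have more. Where it says the series, first, only, none or still open, it means among the compounds named here.

Measured in a functional assay (aorta) for inhibition, with Rattus norvegicus as the target (a higher number here means a weaker inhibitor, a lower number a stronger inhibitor), for each compound:
- Compound 1 `C/N=C(\S)[C@]1(c2ccncc2)CCCC[S+]1[O-]` gives 25000 nM
- Compound 2 `C/N=C(\S)[C@]1(c2nc3ccccc3s2)CCCC[S+]1[O-]` gives 29000 nM
- Compound 3 `CC/N=C(\S)[C@]1(c2cccnc2)CCCC[S+]1[O-]` gives 300 nM

Compound 3 has the lowest of the three numbers, which makes it the strongest inhibitor so far. Its gaps to compound 1 and compound 2 both lie beyond the usual scatter.

The next compound is compound 4 `CNC(=O)[C@]1(c2cccnc2)CCCC[S+]1[O-]` and the structural change is a group of 4 heavy atoms (2 carbon, 1 nitrogen, 1 oxygen; no ring) in place of a group of 5 heavy atoms (3 carbon, 1 nitrogen, 1 sulfur; no ring), on a saturated ring carbon on a saturated ring carbon of a six-membered non-aromatic ring with 1 sulfur. Methylcarbamoyl is the entering group. For the measured compounds named here, no measured pair isolates this exchange, so the direction is a judgement. Going by the values given here, compound 3 at 300 nM is the only low number of the three, and compound 1 at 25000 nM shows how much higher a number can lie. The expected step is a 27-fold higher number from compound 3 to compound 4 (1.43 log units; beyond the scatter) in the estimate, toward a higher number and a weaker inhibitor, beyond the scatter. In this assay the estimate for compound 4 is 8000 nM with an expected range from 1500 nM to 40000 nM as the likely span.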

Compound 4, concentration for 90% inhibition: > 30000 nM
Compound 4 ended at the assay's limit (the forecaster's own chance of this, stated with the estimate: 15%); middle value at least 3.7-fold (0.57 log units) from the limit.
By their numbers in this assay, from the lowest: compound 3; then compounds 1 and 2 (each within the scatter of the next). At a limit, above all of these: compound 4.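

In this assay, for the compounds shown here, replacing the group of 5 heavy atoms with methylcarbamoyl on a saturated ring carbon gives an at least 100-fold higher number from compound 3 to compound 4 (2.00 log units; beyond the scatter), the first step that changes one place only, and a large one. The value of compound 4 is a limit and not a number: the limit of > 30000 nM in this assay, at which 1 of the 4 values shown sits. Both groups count the same hydrogen-bond donors and acceptors and carry no ring or net charge, so these counts do not account for the step.

The exchange alters two things at once, since the group that leaves holds one more carbon and a sulfur where methylcarbamoyl holds oxygen, and the compounds shown do not separate the two. As far as these compounds go, how a longer chain, an amine or a carboxylic acid at this place would read in this assay also remains open.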